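The compounds below may be only part of what the source reports. "The series", "measured", "known", "first", "only" and "open" are said of these compounds alone.

Measured in a functional assay on HepG2 cells (Homo sapiens) for antiproliferative activity, with a stated time of 72 h; a lower number here means that less compound is needed, a higher number that more compound is needed for the effect:
Compound 1 `COc1ccc(-c2cc(=O)c3c(OC)cc(OC)cc3n2Cc2ccccc2)cc1`: > 17300 nM
Compound 2 `COc1ccc(-c2cc(=O)c3c(OC)cc(OC)cc3n2S(=O)(=O)c2ccc([N+](=O)[O-])cc2)cc1`: > 29300 nM
Compound 3 `COc1ccc(-c2cc(=O)c3c(OC)cc(OC)cc3n2S(=O)(=O)c2ccc(C#N)cc2)cc1`: > 17200 nM

All three values are limits, not numbers, so the compounds cannot be ranked. Compound 3 stands only at its limit of > 17200 nM. Compound 4 `COc1ccc(-c2cc(=O)c3c(OC)cc(OC)cc3n2S(=O)(=O)c2ccc(C)cc2)cc1` carries methyl in place of cyano on an aromatic carbon, para to a large group (methyl in place of cyano on an aromatic carbon). The nearest measured change is a step that the two limits leave unreadable from compound 2 to compound 3, which swaps nitro for cyano on that same carbon. The other is a step that the two limits leave unreadable from compound 1 to compound 3. Neither gives a size, so no readable step and no direction is expected in this assay, and compound 4 is expected to return a limit too. The expected change is a step that the limit leaves unreadable from compound 3 to compound 4, a figure that rests on limits alone. For compound 4 the estimated value is 20000 nM, with an expected range from 8000 nM to 40000 nM.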

Compound 4, half-maximal effective concentration: > 44800 nM
Compound 4 ended at the assay's limit; the forecaster's own chance of this, stated with the estimate: 80%; middle value at least 2.2-fold (0.35 log units) from the limit.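

For the compounds shown here, compound 4 also gives only a limit in this assay, so no step to it from compound 1, compound 2 or compound 3 can be read. The compounds shown leave open whether changing the group on the aromatic nitrogen alters the effect at all.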